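A Longer Chain on Compound 2: What to Expect

The source may hold more compounds than are shown below. What is called first, only, known or untested is meant among the compounds shown, and "the series" means these compounds.

In a functional assay on FL5.12 cells (Mus musculus) for cytotoxicity, read by flow cytometry, with a stated time of 48 h (on this read-out lower numbers stand for stronger inhibition and higher numbers for weaker inhibition), compound 1 `CCCC/C=C/c1ccc(CO[C@@H]2CN[C@@H](CO)C2)cc1` gives 5500 nM and compound 2 `CCCCCCCCCC/C=C/c1ccc(CO[C@@H]2CN[C@@H](CO)C2)cc1` gives 2800 nM. Among the compounds with values here, these two numbers lie within the usual scatter of repeated measurements, so compound 2 cannot be ranked apart from the only other compound measured so far. Compound 3 `CCCCCCCCCCCC/C=C/c1ccc(CO[C@@H]2CN[C@@H](CO)C2)cc1` keeps the shared core and extends the chain of compound 2: ethyl in place of hydrogen on a saturated chain carbon, ten or more bonds along the chain from a double-bonded chain carbon.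

Within the data shown here, one measured step bears on this change, and it lengthens the same chain. Hexyl in place of hydrogen on a saturated chain carbon, four bonds along the chain from a double-bonded chain carbon, gave a 2.0-fold lower number from compound 1 to compound 2 (0.29 log units; within the scatter). Since that addition of hexyl produced only a 2.0-fold lower number from compound 1 to compound 2 (0.29 log units; within the scatter), the smaller addition of ethyl is expected to produce no step beyond the scatter in this assay. A single step cannot show whether the chain length will keep having so little effect, so the range is kept wide. The expected change is a 1.2-fold lower number from compound 2 to compound 3 (0.07 log units; within the scatter). Compound 3 is estimated at 2400 nM, with an expected range of 1200 nM to 5000 nM.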

Compound 3, half-maximal inhibitory concentration: 5100 nM
Beside the measured number, compound 3's estimate is 2.1-fold (0.33 log units) below it, outside the stated range (above it).
By their numbers in this assay, from the lowest: compounds 2, 3 and 1 (each within the scatter of the next).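

In this assay, ethyl in place of hydrogen on a saturated chain carbon, ten or more bonds along the chain from a double-bonded chain carbon, gave a 1.8-fold higher number from compound 2 to compound 3 (0.26 log units; within the scatter), so a second lengthening of this chain has also stayed within the scatter. The longer addition of octyl, on a saturated chain carbon four bonds along the chain from a double-bonded chain carbon, gave a 1.1-fold lower number from compound 1 to compound 3 (0.03 log units; within the scatter), which means that the three chain lengths cannot be told apart in this read-out and that compound 2 cannot be taken as a best length. Nothing measured alongside these numbers offers an explanation for how little they separate.

Going by these compounds, whether a shorter chain, or an amine or a carboxylic acid placed on this chain, would give a step beyond the scatter stays open. Also open, on these data alone, is whether a still longer chain would remain within the scatter of compound 1, compound 2 and compound 3.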